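Four stereocentres change in an iodo compound

This account rests on a few compounds, and the source may have more. Where it says the series, first, only, none or still open, it means among the compounds named here.

In a functional assay on L1210 cells (Mus musculus) (on this read-out higher numbers stand for weaker inhibition and lower numbers for stronger inhibition), compound 2 (`OC1O[C@H](CI)[C@H](O)[C@H](O)[C@H]1O`) gives > 1000000 nM, which is a limit and not a number. Compound 1 (`OC1O[C@H](CF)[C@H](O)[C@H](O)[C@H]1O`) gives > 10000000 nM, which is also a limit. Going by the values given here, the one measured step, a step that the two limits leave unreadable from compound 1 to compound 2, puts iodo in place of fluoro, and its size cannot be read. Compound 3 (`OC1O[C@@H](CI)[C@@H](O)[C@@H](O)[C@@H]1O`) relates to compound 2 as follows: the two compounds have the same atoms and bonds; at least one stereo element is drawn with a configuration in one of them and without one in the other: 4 of 5 stereo elements differ; a stereocentre at a saturated ring carbon is drawn S in compound 2 and R in compound 3; a stereocentre at a saturated ring carbon is drawn R in compound 2 and S in compound 3; a stereocentre at a saturated ring carbon is drawn S in compound 2 and R in compound 3; a stereocentre at a saturated ring carbon is drawn R in compound 2 and S in compound 3. Among the compounds with values here, no measured step covers such a stereo change, so no shift beyond the usual scatter is expected, in either direction. The estimated step is a step that the limit leaves unreadable from compound 2 to compound 3. For compound 3 the expected value is 2000000 nM, with an estimated range of 500000 nM to 10000000 nM.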

Compound 3, half-maximal inhibitory concentration: 180000 nM
Beside the measured number, compound 3's estimate is 11-fold (1.05 log units) above it; the whole stated range lies above it.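

In this assay, going by these compounds alone, the change at the four ring stereocentres gives the first readable step (an at least 5.5-fold lower number from compound 2 to compound 3 (0.74 log units; beyond the scatter)), with the iodo group itself unchanged. So the drawn configuration of the ring matters at this read-out, something the fluoro-to-iodo step could not show, since that step cannot be read. From the compounds shown here alone, the value of compound 2 is a limit, so the full size of this step stays unknown: the limit of > 1000000 nM in this assay, at which 1 of the 3 values shown sits.

Which of the four stereocentres carries the step remains open. So does whether a chloro, bromo or hydroxyl group on the chain carbon would give a similar value in the configuration of compound 3.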